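Swapping chloro for methoxy on a long-chain compound

A few compounds are considered here, and "the series" means these few. Any claim that something is new, unique, unknown or untested is made for them only; others in the source may bear on it.

Compound 1 `CCCCC(CCO)n1cnc2c(OC)ncnc21`: > 50000 nM (a limit)
Compound 2 `CCCCCCCCC(CCO)n1cnc2c(OC)ncnc21`: 24600 nM
Compound 3 `CCCCCCCCCC(CCO)n1cnc2c(Cl)ncnc21`: 1150 nM

Among the compounds with values here, in a functional assay on SW480 cells (Homo sapiens) for antiproliferative activity, read by MTT assay, with a stated time of 48 h (on this read-out higher numbers stand for weaker inhibition and lower numbers for stronger inhibition), compound 3 gives 1150 nM, the lowest of the numbers so far. Compound 2 gives 24600 nM, a clearly higher number. Compound 1 gives > 50000 nM, which is a limit of the assay and not a number.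

Compound 4 `CCCCCCCCCC(CCO)n1cnc2c(OC)ncnc21` keeps the chain of compound 3 and changes one group: methoxy in place of chloro on an aromatic carbon.

Within the data shown here, only one measured step exists, an at least 2.0-fold lower number from compound 1 to compound 2 (0.30 log units; that floor lies within the scatter). It rests on (the limit of > 50000 nM in this assay, at which 1 of the 3 values shown sits), so it gives a floor and not a true size. Among the measured compounds shown here, it also concerns the chain, and no measured step isolates the swap from chloro to methoxy.

Compound 4 carries methoxy, and the best guide is therefore compound 2, which carries it too and stands at 24600 nM. Compound 4 should land nearer to that number than to the value of compound 3, though its longer chain may keep it somewhat lower. The expected change is a 10-fold higher number from compound 3 to compound 4 (1.02 log units; beyond the scatter), towards weaker inhibition. For compound 4 the estimate is 12000 nM, with an expected range from 4000 nM to 30000 nM.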

Compound 4, half-maximal inhibitory concentration: 3250 nM
Compound 4: the middle estimate sits 3.7-fold (0.57 log units) above what was measured, and the stated range ends above it.
By their numbers in this assay, from the lowest: compound 3; then compound 4; then compound 2. At a limit, above all of these: compound 1.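

In this assay, the swap of chloro for methoxy on an aromatic carbon now has a measured size with the chain held constant: a 2.8-fold higher number from compound 3 to compound 4 (0.45 log units; beyond the scatter). The change is modest but real, so methoxy weakens inhibition here without removing it, at least on this long chain. The chain also matters among the methoxy compounds, with a 7.6-fold lower number from compound 2 to compound 4 (0.88 log units; beyond the scatter) and an at least 15-fold lower number from compound 1 to compound 4 (1.18 log units; beyond the scatter), and the order of compound 1, compound 2 and compound 4 shows no exception to lower numbers with longer chains, though the last step is a floor and not a true size: the limit of > 50000 nM in this assay, at which 1 of the 4 values shown sits.

The compounds shown do not tell whether a different group on that aromatic carbon, such as an amine or a thioether, would give a lower or a higher number than chloro or methoxy. They also leave open whether a longer chain than that of compound 4 would lower the number further, and whether the swap from chloro to methoxy would have the same size on a shorter chain.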